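The compounds below may be only part of what the source reports. "The series", "measured", "known", "first", "only" and "open" are said of these compounds alone.

Measured in a functional assay on A549 cells (Homo sapiens) for antiproliferative activity, read by MTT assay, with a stated time of 48 h; on this read-out higher numbers stand for weaker inhibition and lower numbers for stronger inhibition:
- compound 1 `Cc1ccc2nc(NC(c3cn(-c4ccccc4)nc3-c3cccc([N+](=O)[O-])c3)c3c(O)ccc4ccccc34)sc2c1`: 57400 nM
- compound 2 `Cc1cccc(-c2nn(-c3ccccc3)cc2C(Nc2nc3ccccc3s2)c2c(O)ccc3ccccc23)c1`: 18500 nM

Of these two numbers, the lower belongs to compound 2 at 18500 nM, and its gap to compound 1 at 57400 nM lies beyond the scatter. Next in the series is compound 3 `Oc1ccc2ccccc2c1C(Nc1nc2ccccc2s1)c1cn(-c2ccccc2)nc1-c1ccc(I)cc1`, which has 4-iodophenyl in place of 3-methylphenyl on an aromatic carbon of the five-membered aromatic ring with 2 nitrogen (4-iodophenyl in place of 3-methylphenyl on an aromatic carbon). Among the measured compounds shown here, no measured pair differs in one place, so nothing yet shows what this exchange does. The working assumption is that compound 3 stays close to compound 2 at 18500 nM, with no step beyond the scatter expected in this assay in either direction. The estimated step is a 1.1-fold higher number from compound 2 to compound 3 (0.03 log units; within the scatter). For compound 3 the expected value is 20000 nM, with an estimated range from 7000 nM to 55000 nM.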

Compound 3, half-maximal inhibitory concentration: 23100 nM
Estimate against measurement, compound 3: 1.2-fold (0.06 log units) below, within the range that was stated.
By their numbers in this assay, from the lowest: compounds 2 and 3 (each within the scatter of the next); then compound 1.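

Among the compounds shown here, this is the first pair that differs in one place. In this assay the exchange of 3-methylphenyl for 4-iodophenyl on an aromatic carbon of the five-membered aromatic ring with 2 nitrogen gives a 1.2-fold higher number from compound 2 to compound 3 (0.10 log units; within the scatter) and so does not separate the two groups at this position. The substituent and its place on the phenyl ring change together here, so neither can be read alone, and nothing at hand bears on why the two groups read alike.

Still open, going by these compounds, is what an amine or a carboxylic acid on this phenyl ring would do, as is the reading of an unsubstituted phenyl at this position. Also open, on these data alone, is whether the same exchange reads alike when the rest of the core is changed.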